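Two benzhydryl ester penam enones on OE19 cells

A few compounds are considered here, and "the series" means these few. Any claim that something is new, unique, unknown or untested is made for them only; others in the source may bear on it.

Measured compounds:
compound 1, `CC1(C)S[C@@H]2/C(=C\C(=O)c3ccc4ccccc4c3)C(=O)N2[C@H]1C(=O)OC(c1ccccc1)c1ccccc1`, 19500 nM
compound 2, `CC1(C)S[C@@H]2/C(=C\C(=O)OC(c3ccccc3)c3ccccc3)C(=O)N2[C@H]1C(=O)OC(c1ccccc1)c1ccccc1`, 21600 nM

Both compounds were tested in a functional assay on OE19 cells (Homo sapiens) for cytotoxicity, read by MTT assay, with a stated time of 48 h; on this read-out lower numbers stand for stronger inhibition and higher numbers for weaker inhibition. Compound 1 gives 19500 nM and compound 2 gives 21600 nM; the gap between them lies within the scatter of repeated measurements, so neither can be called the more potent of the two. Compound 1 stands with the lower of the two numbers, with compound 2 close beside it.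

The next step leads from compound 1 to compound 3, `CC1(C)S[C@@H]2/C(=C\C(=O)c3ccc(Br)cc3)C(=O)N2[C@H]1C(=O)OC(c1ccccc1)c1ccccc1`, which has not yet been measured. The change is 4-bromophenyl in place of naphthalen-2-yl on a carbonyl carbon. Among the compounds with values here, with no measured step of comparable kind to draw on, the expectation rests on the shared core alone, which in compound 1 and compound 2 gives closely similar numbers. The step of a 1.3-fold higher number from compound 1 to compound 3 (0.11 log units; within the scatter) is expected to stay within the scatter or to weaken inhibition only slightly. Compound 3 is estimated at 25000 nM, with a range from 10000 nM to 60000 nM.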

Compound 3, half-maximal inhibitory concentration: 13800 nM
Compound 3: middle estimate off by 1.8-fold (0.26 log units), on the high side; measured number inside the range.
By their numbers in this assay, from the lowest: compounds 3, 1 and 2 (each within the scatter of the next).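

In this assay the exchange of naphthalen-2-yl for 4-bromophenyl on a carbonyl carbon gives a 1.4-fold lower number from compound 1 to compound 3 (0.15 log units; within the scatter) and is the first step shown at this position. It shows that one six-membered aromatic ring carrying bromine can stand in place of the two aromatic rings of naphthalen-2-yl, and that the numbers remain within the scatter of each other. No measurement bears on why this is so.

The compounds shown leave open whether an unsubstituted phenyl, a pyridine ring or an amine on this carbonyl carbon would give a number in the same range, and so whether the bromine matters at all. They also leave open what a free carboxylic acid in place of the benzhydryl ester would do.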